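The source may hold more compounds than are shown below. What is called first, only, known or untested is meant among the compounds shown, and "the series" means these compounds.

Three compounds share a core in which a five-membered aromatic ring with two nitrogens carries a carboxy group and a benzyl-type arm bearing a bromo substituent and a benzyloxy group. Compound 1 `Cc1cc(C(=O)O)nn1Cc1cc(Br)ccc1OCc1ccccc1` differs from the others in where the methyl and the carboxy group sit on that ring. Compound 2 `O=C(O)c1nn(Cc2cc(Br)ccc2OCc2ccccc2)cc1F` carries a fluoro group on the ring, and compound 3 `Cc1cn(Cc2cc(Br)ccc2OCc2ccccc2)nc1C(=O)O` carries a methyl in its place.

In an assay on CHO-K1 cells for displacement of a labelled ligand from prostaglandin E2 receptor EP1 subtype (Homo sapiens) (on this read-out higher numbers stand for weaker inhibition and lower numbers for stronger inhibition), compound 1 gives 6.46 nM. Compound 2 gives 123 nM, and compound 3 gives 427 nM. Compound 2 therefore stands second highest of the three numbers, well apart from compound 1 and closer to compound 3.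

The new compound 4 `O=C(O)c1nn(Cc2cc(Br)ccc2OCc2ccccc2)cc1C(F)(F)F` changes compound 2 in one place: trifluoromethyl in place of fluoro on an aromatic carbon.

Among the measured compounds shown here, only one measured step bears on this change. It is a 3.5-fold higher number from compound 2 to compound 3 (0.54 log units; beyond the scatter), where a group larger than fluoro at the same place gave a higher number. Trifluoromethyl is larger again, so the same direction is expected, with a step at least as large. The step from compound 2 to compound 4 is estimated at a 3.7-fold higher number from compound 2 to compound 4 (0.56 log units; beyond the scatter). Compound 4 is thus expected to give about 450 nM, within a range from 130 nM to 1600 nM.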

Compound 4, half-maximal inhibitory concentration: 2570 nM
For compound 4 the middle estimate is 5.7-fold (0.76 log units) below the measured one; measured number above the stated range.
By their numbers in this assay, from the lowest: compound 1; then compound 2; then compound 3; then compound 4.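

In this assay, among the compounds shown here, the aromatic carbon next to the ring atom that bears a carboxy group turns out to respond far more strongly to the group placed on it than the earlier compounds showed. Trifluoromethyl in place of fluoro gives a 21-fold higher number from compound 2 to compound 4 (1.32 log units; beyond the scatter) and counts as a large step, well beyond the modest one seen with methyl. Trifluoromethyl in place of methyl at the same carbon gives a 6.0-fold higher number from compound 3 to compound 4 (0.78 log units; beyond the scatter) and so places fluoro, methyl and trifluoromethyl in one order across compound 2, compound 3 and compound 4, with inhibition weakening along that series.

Nothing in the data given accounts for the size of these steps. As far as these compounds go, whether hydrogen, chloro, a nitrile or an amine on this carbon would fit that order or break it stays open, as does whether the same change would have a similar effect with the methyl and carboxy groups arranged as in compound 1, which still gives the lowest number of the four.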